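From Trifluoromethyl to Butyl: Expecting Compound 3

A few compounds are considered here, and "the series" means these few. Any claim that something is new, unique, unknown or untested is made for them only; others in the source may bear on it.

Two measured compounds share one core and differ in a single group on an aromatic ring. Compound 1 `COc1ccc(S(=O)(=O)NCCCCCCNCc2ccc(Br)cc2)cc1` gives 13000 nM in a functional assay on MIA PaCa-2 cells (Homo sapiens) for inhibition, read by MTT assay, with a stated time of 72 h (a lower number here means a stronger inhibitor of growth, a higher number a weaker inhibitor of growth), while compound 2 `O=S(=O)(NCCCCCCNCc1ccc(Br)cc1)c1ccc(C(F)(F)F)cc1` gives 3830 nM. That exchange produced a 3.4-fold lower number from compound 1 to compound 2 (0.53 log units; beyond the scatter). Among the two numbers available, compound 2 therefore stands lowest, with compound 1 as its only neighbour.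

Compound 3 `CCCCc1ccc(S(=O)(=O)NCCCCCCNCc2ccc(Br)cc2)cc1` carries butyl in place of trifluoromethyl on an aromatic carbon. For the measured compounds named here, the only measured step concerns a different exchange, methoxy for trifluoromethyl, so it offers no direct guide for replacing trifluoromethyl with butyl; it shows merely that a changed group at this position shifted this assay by a modest amount. A shift no larger than that, in either direction, is expected here. Compound 3 is expected to give 3500 nM, within a range from 1200 nM to 10000 nM. This estimate amounts to the expected step of a 1.1-fold lower number from compound 2 to compound 3 (0.04 log units; within the scatter).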

Compound 3, concentration for 50% growth inhibition: 5700 nM
Beside the measured number, compound 3's estimate is 1.6-fold (0.21 log units) below it; the measured number falls inside the stated range.
By their numbers in this assay, from the lowest: compounds 2 and 3 (each within the scatter of the next); then compound 1.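

Swapping trifluoromethyl for butyl on this aromatic carbon gives a 1.5-fold higher number from compound 2 to compound 3 (0.17 log units; within the scatter) in this assay, so these two groups cannot be told apart here, although one is built of carbon and fluorine and the other of carbon alone. Butyl in place of methoxy gives a 2.3-fold lower number from compound 1 to compound 3 (0.36 log units; beyond the scatter) and is a modest change, so compound 1 now stands apart from both other compounds and not from compound 2 alone. Nothing at hand explains why methoxy differs from the other two groups.

As far as these compounds go, it remains open how an amine or a carboxylic acid would read on this same carbon. From the compounds shown here alone, it is also open whether a chain longer than butyl would stay within the scatter of compound 2 or move clearly away from it.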